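This account rests on a few compounds, and the source may have more. Where it says the series, first, only, none or still open, it means among the compounds named here.

Measured so far in a functional assay (HSMC cells, Homo sapiens) for antiproliferative activity, with a stated time of 72 h; on this read-out higher numbers stand for weaker inhibition and lower numbers for stronger inhibition:

compound 1, `COC(=O)CNC(=O)c1ccc(OC[C@@H]2COc3ccccc3O2)cc1-c1ccccc1C`: 700 nM
compound 2, `COC(=O)CNC(=O)c1ccc(OC[C@@H]2COc3ccccc3O2)cc1-c1ccccc1OC`: 35000 nM
compound 3, `COC(=O)[C@H](CC(C)C)NC(=O)c1ccc(C(=O)NC[C@H]2COc3ccccc3O2)cc1-c1ccccc1C`: 103000 nM

Compound 1 and compound 2 share one core and differ only by methoxy in place of methyl on an aromatic carbon. That change gave a 50-fold higher number from compound 1 to compound 2 (1.70 log units; beyond the scatter). Compound 3 sits on a different core; the difference between the core of compound 1 and the core of compound 3 is not broken down here. In this assay compound 3 gives the highest of the three numbers, and its gap to compound 2 and to compound 1 is beyond the scatter in both cases.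

Compound 4, `COC(=O)[C@H](CC(C)C)NC(=O)c1ccc(C(=O)NC[C@H]2COc3ccccc3O2)cc1-c1ccccc1OC`, has not been measured. It differs from compound 3 by methoxy in place of methyl on an aromatic carbon, the same change as from compound 1 to compound 2, at a place described in the same words. The expected step of a 5.8-fold higher number from compound 3 to compound 4 (0.77 log units; beyond the scatter) is set in the same direction as the earlier one, because a 50-fold higher number from compound 1 to compound 2 (1.70 log units; beyond the scatter) was large; it is drawn somewhat smaller since compound 3 already stands high at 103000 nM. Compound 4 is expected to give 600000 nM. For compound 4 the expected span runs from 150000 nM to 3000000 nM.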

Compound 4, half-maximal inhibitory concentration: 185000 nM
Compound 4: middle estimate off by 3.2-fold (0.51 log units), on the high side; the range from low to high includes it.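

In this assay, methoxy in place of methyl on an aromatic carbon gives a 1.8-fold higher number from compound 3 to compound 4 (0.25 log units; within the scatter), so on this core the change cannot be told apart from the scatter. The change therefore does not carry its size from one core to the other, and the two steps differ clearly: the same change on two cores in this assay, a 50-fold higher number (1.70 log units; beyond the scatter) from compound 1 to compound 2 and a 1.8-fold higher number (0.25 log units; within the scatter) from compound 3 to compound 4, 28-fold (1.44 log units) apart, beyond the scatter of two such steps. Going by these compounds alone, this shows that the large step on the core of compound 1 cannot be assumed on another core, but each core supplies only one pair, so it does not show how the step behaves on any further core or what in the cores goes with the gap.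

Open, from the compounds shown here alone, is whether a carboxylic acid in place of the methyl ester, or a chloro or ethyl group in place of the methyl on the aromatic carbon, would follow the large step or the small one. Also open, going by these compounds, is which part of the difference between the two cores goes with the smaller step.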